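Carbamate series on PANC-1: anilide swap on the prenyl core

The source may report more compounds than this note shows. Statements on the series, on what has been measured and on what is new or still open speak of the compounds shown alone.

Three carbamates of one shared core have been measured in a functional assay on PANC-1 cells (Homo sapiens) for inhibition, read by MTT assay, with a stated time of 24 h, tested at 10 uM; a higher number here means more inhibition at the concentration tested (going by the name of the read-out), a lower number less inhibition. Compound 1 `CC(C)=CCC1Cc2c(OC(=O)Nc3ccc(F)c(Cl)c3)cc(=O)n(CCCO)c2CC1(C)C` gives 0%, compound 2 `CC(C)=CCC1Cc2c(OC(=O)Nc3ccc(Cl)cc3)cc(=O)n(CCCO)c2CC1(C)C` gives 0% and compound 3 `CC(C)=CCC/C(C)=C/CC1Cc2c(OC(=O)Nc3ccc(F)c(Cl)c3)cc(=O)n(CCCO)c2CC1(C)C` gives 0% in this assay. The step of no change at the digits printed from compound 1 to compound 2 (within the scatter) comes from the change (4-chlorophenyl in place of 3-chloro-4-fluorophenyl on an amide-type nitrogen). The cores of compound 1 and compound 3 differ by 3-methylbut-2-en-1-yl in place of hydrogen on a saturated chain carbon bound to a double-bonded chain carbon, and that step reads no change at the digits printed from compound 1 to compound 3 (within the scatter). Compound 4 `CC(C)=CCC/C(C)=C/CC1Cc2c(OC(=O)Nc3ccc(Cl)cc3)cc(=O)n(CCCO)c2CC1(C)C` is not yet measured; it differs from compound 3 by 4-chlorophenyl in place of 3-chloro-4-fluorophenyl on an amide-type nitrogen, the same change as from compound 1 to compound 2, at the same place, an amide-type nitrogen whose other neighbour is a carbonyl carbon. The step for compound 4 is expected as no change at the digits printed from compound 3 to compound 4 (within the scatter), resting on the earlier step of no change at the digits printed from compound 1 to compound 2 (within the scatter) and on compound 3 at 0%. Compound 4 is therefore estimated at 0%, between 0% and 10%.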

Compound 4, a percentage reported as inhibition, at one concentration (the size of the read-out at that concentration, not a potency): 4.3%
Estimate against measurement, compound 4: 4.3 percentage points below; the range from low to high includes it.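

In this assay, 4-chlorophenyl in place of 3-chloro-4-fluorophenyl on the amide-type nitrogen gives a number 4.3 percentage points higher from compound 3 to compound 4 (within the scatter), and this reads the same as on the other core: the same change on two cores in this assay, no change at the digits printed (within the scatter) from compound 1 to compound 2 and a number 4.3 percentage points higher (within the scatter) from compound 3 to compound 4, 4.3 percentage points apart, within the scatter of two such steps

Likewise, 3-methylbut-2-en-1-yl in place of hydrogen gives a number 4.3 percentage points higher from compound 2 to compound 4 (within the scatter), again matching its earlier step: the same change on two cores in this assay, no change at the digits printed (within the scatter) from compound 1 to compound 3 and a number 4.3 percentage points higher (within the scatter) from compound 2 to compound 4, 4.3 percentage points apart, within the scatter of two such steps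

For the compounds shown here, with so little inhibition on all four compounds, this shows only that neither change lifts the read-out on either core, not that the changes would carry over the same way on a compound with substantial inhibition.

Still open, on these data alone, is whether a phenyl bearing an amine or a carboxylic acid in place of 4-chlorophenyl would give any inhibition in this assay. The compounds shown give no sign of which part of the structure could raise the read-out.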